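Vinyl in place of phenoxy on compound 2

The compounds below may be only part of what the source reports. "The series", "measured", "known", "first", "only" and "open" are said of these compounds alone.

In a functional assay on HT-29 cells (Homo sapiens) for inhibition, read by sulforhodamine B assay, with a stated time of 72 h (on this read-out higher numbers stand for weaker inhibition and lower numbers for stronger inhibition), compound 2 `CCOc1ccc(C2C(Oc3ccccc3)C(=O)N2c2cc(OC)c(OC)c(OC)c2)cc1` gives 388 nM, which lies within the scatter of compound 1 `C=CC1C(=O)N(c2cc(OC)c(OC)c(OC)c2)C1c1ccc(SCC)cc1` at 257 nM. Compound 3 `C=CC1C(=O)N(c2cc(OC)c(OC)c(OC)c2)C1c1ccc(OCC)cc1` is derived from compound 2 by one change: vinyl in place of phenoxy on a saturated ring carbon, with vinyl in place of phenoxy on a saturated ring carbon. Among the compounds with values here, no measured pair shows this change directly. Within the data shown here, the only measured compound with vinyl at that place is compound 1, at 257 nM. In this assay a modest step toward stronger inhibition is therefore expected, a 1.9-fold lower number from compound 2 to compound 3 (0.29 log units; within the scatter), close to the scatter. Compound 3 is estimated at 200 nM, with an expected range of 60 nM to 600 nM.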

Compound 3, half-maximal inhibitory concentration: 97 nM
Beside the measured number, compound 3's estimate is 2.1-fold (0.31 log units) above it; low and high end bracket the measured number.
By their numbers in this assay, from the lowest: compound 3; then compounds 1 and 2 (each within the scatter of the next).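

Working from this assay, vinyl in place of phenoxy on the saturated ring carbon gives a 4.0-fold lower number from compound 2 to compound 3 (0.60 log units; beyond the scatter) and so separates this position from the rest of the molecule for the first time. With vinyl held in place, ethoxy in place of ethylsulfanyl on the aromatic carbon gives a 2.6-fold lower number from compound 1 to compound 3 (0.42 log units; beyond the scatter) as a second step beyond the scatter, which the closeness of compounds 1 and 2 had not revealed. Nothing at hand accounts for either step. From the compounds shown here alone, whether an amine, a hydroxyl or a longer chain at the saturated ring carbon would keep the number of compound 3 stays open. Going by these compounds, whether the ethoxy step holds with phenoxy at that carbon also stays open.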